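A few compounds are considered here, and "the series" means these few. Any claim that something is new, unique, unknown or untested is made for them only; others in the source may bear on it.

In a functional assay on HL-60 cells (Homo sapiens) for cytotoxicity, read by MTT assay, with a stated time of 48 h (on this read-out lower numbers stand for stronger inhibition and higher numbers for weaker inhibition), compound 3 `CCCCCCCC(=O)NCC(=O)N[C@@H](C)C(=O)N[C@@H](CC(C)C)C(=O)NC(C)(C)C(=O)N[C@@H](C)C(=O)N[C@H](C(=O)N[C@H](CO)CC(C)C)[C@@H](C)CC` gives 16000 nM, and compound 2 `CCCCCCCC(=O)NCC(=O)N[C@@H](C)C(=O)N[C@@H](CC(C)C)C(=O)N[C@](C)(CC)C(=O)N[C@@H](CO)C(=O)N[C@H](C(=O)N[C@H](CO)CC(C)C)[C@@H](C)CC` gives 2000 nM, so compound 3 holds the higher of the two actual numbers. Compound 1 `CCCCCCCC(=O)NCC(=O)N[C@@H](C)C(=O)N[C@@H](CC(C)C)C(=O)NC(C)(C)C(=O)N[C@@H](CO)C(=O)N[C@H](C(=O)N[C@H](CO)CC(C)C)[C@@H](C)CC` gives > 30000 nM, which is a limit of the assay and not a number.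

Compound 4 `CCCCCCCC(=O)NCC(=O)N[C@@H](C)C(=O)N[C@@H](CC(C)C)C(=O)N[C@](C)(CC)C(=O)N[C@@H](C)C(=O)N[C@H](C(=O)N[C@H](CO)CC(C)C)[C@@H](C)CC` departs from compound 3 by one change: methyl in place of hydrogen on a saturated chain carbon, two bonds along the chain from an amide-type nitrogen and a carbonyl carbon. This places methyl in place of hydrogen on a saturated chain carbon, two bonds along the chain from an amide-type nitrogen and a carbonyl carbon.

The same change has been measured once, on the hydroxy-bearing peptide, and there it gave a large step, an at least 15-fold lower number from compound 1 to compound 2 (1.17 log units; beyond the scatter). That size is a floor, not an exact figure, since it starts from a limit. The other measured step, an at least 1.8-fold lower number from compound 1 to compound 3 (0.27 log units; that floor lies within the scatter), replaces hydroxy with hydrogen, and its floor lies within the scatter. Within the data shown here, it shows only that the change can be made without loss in this assay. Whether the gain seen in compound 2 carries over to a peptide without the hydroxy has not been tested, so a clear but somewhat uncertain drop is expected.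

The expected move is a 6.4-fold lower number from compound 3 to compound 4 (0.81 log units; beyond the scatter). For compound 4 the estimated value is 2500 nM, with an expected range from 700 nM to 9000 nM.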

Compound 4, half-maximal inhibitory concentration: 4000 nM
The estimate for compound 4 lay 1.6-fold (0.20 log units) below the measured number; low and high end bracket the measured number.
By their numbers in this assay, from the lowest: compounds 2 and 4 (each within the scatter of the next); then compound 3. At a limit, above all of these: compound 1.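

The methyl in place of hydrogen on a saturated chain carbon, two bonds along the chain from an amide-type nitrogen and a carbonyl carbon, also lowers the number on the core without the hydroxy, with a 4.0-fold lower number from compound 3 to compound 4 (0.60 log units; beyond the scatter) in this assay, so the gain seen on the hydroxy-bearing peptide is not confined to that peptide. The size of this gain nevertheless differs between the two cores: the same change on two cores in this assay, an at least 15-fold lower number (1.17 log units; beyond the scatter) from compound 1 to compound 2 and a 4.0-fold lower number (0.60 log units; beyond the scatter) from compound 3 to compound 4, at least 3.7-fold (0.57 log units) apart, beyond the scatter of two such steps With the methyl in place, hydrogen in place of hydroxy gives a 2.0-fold higher number from compound 2 to compound 4 (0.30 log units; within the scatter), so the swap shows no clear effect on this core, and its two readings do not agree: the same change on two cores in this assay, an at least 1.8-fold lower number (0.27 log units; that floor lies within the scatter) from compound 1 to compound 3 and a 2.0-fold higher number (0.30 log units; within the scatter) from compound 2 to compound 4, at least 3.7-fold (0.57 log units) apart, beyond the scatter of two such steps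

From the compounds shown here alone, how large the steps from compound 1 truly are stays open, since compound 1 gives > 30000 nM, a limit and not a number. Also open, going by these compounds, is whether a longer chain or an amine on this saturated chain carbon would lower the number further, and whether either would behave alike with hydroxy and with hydrogen on the other chain carbon.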